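The source may hold more compounds than are shown below. What is called first, only, known or untested is meant among the compounds shown, and "the series" means these compounds.

In a physicochemical assay for lipophilicity, read by HPLC, measured as octanol-water partition (a higher number here means a more lipophilic compound, a lower number a more polar compound), two compounds built on one shared core have been measured. Compound 1 `CN1CCN(C[C@H]2CN(c3ccc(-n4cc(-c5ccccn5)cn4)c(F)c3)C(=O)O2)CC1` gives 2.2, and compound 2 `O=C1CCC(=O)N1C[C@H]1CN(c2ccc(-n3cc(-c4ccccn4)cn3)c(F)c2)C(=O)O1` gives 1.58, the lower of the two numbers. Among the compounds with values here, the only measured step is a number 0.62 log units lower from compound 1 to compound 2 (beyond the scatter), with 2,5-dioxopyrrolidin-1-yl in place of 4-methylpiperazin-1-yl on a saturated chain carbon bound to a saturated ring carbon.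

Compound 3 `COC[C@H]1CN(c2ccc(-n3cc(-c4ccccn4)cn3)c(F)c2)C(=O)O1` has yet to be measured in this assay. It differs from compound 2 at that same place: methoxy in place of 2,5-dioxopyrrolidin-1-yl on a saturated chain carbon bound to a saturated ring carbon. Here methoxy stands in place of 2,5-dioxopyrrolidin-1-yl. Within the data shown here, the measured step bears on this change only in part, as it shows that the number moves at this place but contains no compound with methoxy. With compound 2 the lower of the pair at 1.58, removing its 2,5-dioxopyrrolidin-1-yl is expected to give a rise of about the same modest size as the measured step. The step expected is a number 0.62 log units higher from compound 2 to compound 3 (beyond the scatter). Compound 3 is estimated at 2.2, with an expected range from 1.8 to 2.6.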

Compound 3, partition coefficient: 2.18
Compound 3: middle estimate off by 0.02 log units, on the high side; the measured number falls inside the stated range.
By their numbers in this assay, from the lowest: compound 2; then compounds 3 and 1 (each within the scatter of the next).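

In this assay, the new result adds a small open-chain group at this place, on a saturated chain carbon bound to a saturated ring carbon, and a number 0.60 log units higher from compound 2 to compound 3 (beyond the scatter); the replacement of 2,5-dioxopyrrolidin-1-yl thus gives a clear difference with a second, quite different group, not only with 4-methylpiperazin-1-yl. Methoxy and 4-methylpiperazin-1-yl cannot be told apart, since a number 0.02 log units lower from compound 1 to compound 3 (within the scatter), so among the three compounds it is compound 2, with its 2,5-dioxopyrrolidin-1-yl, that stands apart, while a ring as such does not set the number, as compound 1 carries one and still matches compound 3. No measurement shown here explains why these groups give these numbers.

The compounds shown do not separate the features that leave with 2,5-dioxopyrrolidin-1-yl, namely its ring, its two double bonds and its hydrogen-bond acceptors, so which of them goes with the difference remains unknown. From the compounds shown here alone, how a carboxylic acid, a primary amine or a longer ether chain such as ethoxy would stand at this place also remains open.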